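Lengthening the Chain: From Compound 3 to Compound 4

This account rests on a few compounds, and the source may have more. Where it says the series, first, only, none or still open, it means among the compounds named here.

Of the compounds shown here, three sharing one core have been measured in an in vitro assay on U2OS cells for agonist activity at neurotensin receptor type 2 (Homo sapiens), read by reporter gene assay and beta-arrestin recruitment; a lower number here means that less compound is needed, a higher number that more compound is needed for the effect. Compound 1 `COc1cc2nc(C)nc(N3CCN(c4ccccc4OC)CC3)c2cc1OC` is the simplest of them; in this assay compound 1 gives > 80000 nM, which is a limit of the assay and not a number. Compound 2 `COc1cc2nc(Cc3ccccc3)nc(N3CCN(c4ccccc4OC)CC3)c2cc1OC` carries a phenyl in place of hydrogen on a saturated chain carbon bound to an aromatic carbon; in this assay compound 2 gives > 80000 nM, again a limit. Compound 3 `CCc1nc(N2CCN(c3ccccc3OC)CC2)c2cc(OC)c(OC)cc2n1` carries a methyl in place of that hydrogen; in this assay compound 3 gives > 80000 nM, also a limit. Compound 3 thus stands at the limit where all three values sit (the limit of > 80000 nM in this assay, at which 3 of the 3 values shown sit). The steps a step that the two limits leave unreadable from compound 1 to compound 2, a step that the two limits leave unreadable from compound 1 to compound 3 and a step that the two limits leave unreadable from compound 2 to compound 3 are therefore unreadable in both size and direction. Compound 4 `CCCc1nc(N2CCN(c3ccccc3OC)CC2)c2cc(OC)c(OC)cc2n1` differs from compound 3 by methyl in place of hydrogen on a saturated chain carbon, two bonds along the chain from an aromatic carbon. The steps bearing on this change, a step that the two limits leave unreadable from compound 1 to compound 3 and a step that the two limits leave unreadable from compound 2 to compound 3, give no readable size, so for compound 4 no step beyond the scatter in this assay can be expected, and a limit is again the likely outcome. The estimate for compound 4 is 100000 nM, between 30000 nM and 300000 nM. This corresponds to an expected step that the limit leaves unreadable from compound 3 to compound 4.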

Compound 4, half-maximal effective concentration: > 80000 nM
Compound 4: no number, only a limit; the forecaster's own chance of this, stated with the estimate: 85%; the middle value is on the limit's open side.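

In this assay, for the compounds shown here, compound 4 gives > 80000 nM, again a limit and not a number, so no step from compound 1, compound 2 or compound 3 to compound 4 can be read. The compounds shown leave open whether any group at this place on the shared core gives a readable number in this assay: the limit of > 80000 nM in this assay, at which 4 of the 4 values shown sit.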